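An Ester in Place of the Acid on the Side Chain

The source may report more compounds than this note shows. Statements on the series, on what has been measured and on what is new or still open speak of the compounds shown alone.

Compound 1 `CC1=C(C(=O)OCc2ccccc2)C(c2ccc(Cl)cc2Cl)NC(=O)N1CCCCC(=O)O`: > 100000 nM
Compound 2 `CC1=C(C(=O)OCc2ccccc2)C(c2ccc(Cl)cc2Cl)NC(=O)N1CCCC(=O)OCc1ccccc1F`: > 100000 nM

In an ADME assay on MCF7 cells (Homo sapiens) for cytotoxicity, read by CellTiter-Glo, with a stated time of 24 h (a lower number here means a stronger inhibitor of growth, a higher number a weaker inhibitor of growth), compound 1 gives > 100000 nM, which is a limit of the assay rather than a number. Compound 2 likewise gives > 100000 nM, again a limit. The step that the two limits leave unreadable from compound 1 to compound 2 is therefore unreadable, and the whole picture so far is the limit of > 100000 nM in this assay, at which 2 of the 2 values shown sit.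

Compound 3 `COCCOC(=O)CCCN1C(=O)NC(c2ccc(Cl)cc2Cl)C(C(=O)OCc2ccccc2)=C1C` has not yet been measured. It differs from compound 1 by (2-methoxyethoxy)carbonyl in place of carboxymethyl on a saturated chain carbon, three bonds along the chain from an amide-type nitrogen in a ring. Among the measured compounds shown here, the only measured step bearing on this change is the one from compound 1 to compound 2, a change of the same kind at the same place, and it gave no readable size. Nothing among the shown values points to growth inhibition becoming measurable, so compound 3 is expected to sit at another limit, with an estimated 150000 nM and a range from 70000 nM to 400000 nM. The expected step that the limit leaves unreadable from compound 1 to compound 3 is thus one of no readable size.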

Compound 3, concentration for 50% growth inhibition: > 100000 nM
Compound 3 gave a limit, no number; the forecaster's own chance of this, stated with the estimate: 85%; the middle value does not contradict the limit.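

Compound 3 also gives a limit rather than a number, so no step among compound 1, compound 2 and compound 3 can be read in this assay: the limit of > 100000 nM in this assay, at which 3 of the 3 values shown sit.

The compounds shown leave open whether any side chain on the shared core brings growth inhibition into a readable range, and how the acid and its esters would then compare.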